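Amide aryl variation on the shared core: compound 4

This account rests on a few compounds, and the source may have more. Where it says the series, first, only, none or still open, it means among the compounds named here.

Three amides share one core and differ only in the aryl on the carbonyl carbon. In a functional assay on HepG2 cells (Homo sapiens) for antiproliferative activity, read by CCK-8 assay, with a stated time of 72 h (a higher number here means a weaker inhibitor, a lower number a stronger inhibitor), compound 3 `COc1cccc(C(=O)Nc2cccc(-c3oc4cc(-c5ccc(F)cc5)ccc4c(=O)c3O)c2)c1` gives 9950 nM, the lowest of the three numbers. Compound 1 `Cc1ccccc1C(=O)Nc1cccc(-c2oc3cc(-c4ccc(F)cc4)ccc3c(=O)c2O)c1` gives 19400 nM and compound 2 `O=C(Nc1cccc(-c2oc3cc(-c4ccc(F)cc4)ccc3c(=O)c2O)c1)c1ccc(C(F)(F)F)cc1` gives 42700 nM. The step of a 1.9-fold lower number from compound 1 to compound 3 (0.29 log units; within the scatter); the step of a 4.3-fold lower number from compound 2 to compound 3 (0.63 log units; beyond the scatter). Compound 4 `Cc1cc(C)cc(C(=O)Nc2cccc(-c3oc4cc(-c5ccc(F)cc5)ccc4c(=O)c3O)c2)c1` carries 3,5-dimethylphenyl in place of 3-methoxyphenyl on a carbonyl carbon. Going by the values given here, both earlier swaps of the aryl on the carbonyl carbon moved this assay by at most a modest amount, and no measured step involves a 3,5-dimethylphenyl, so a change within or only just beyond the scatter is expected. Compound 4 is estimated at 12000 nM in this assay, with a range of 5000 nM to 30000 nM, which means an expected step of a 1.2-fold higher number from compound 3 to compound 4 (0.08 log units; within the scatter).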

Compound 4, half-maximal inhibitory concentration: 13400 nM
Estimate against measurement, compound 4: 1.1-fold (0.05 log units) below, and the stated range covers the measured number.
By their numbers in this assay, from the lowest: compounds 3, 4 and 1 (each within the scatter of the next); then compound 2.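

In this assay the 3,5-dimethylphenyl on the carbonyl carbon has no hydrogen-bond acceptor, yet the result is a 1.3-fold higher number from compound 3 to compound 4 (0.13 log units; within the scatter) and so the oxygen of the 3-methoxyphenyl is not required at this level. The step of a 1.4-fold lower number from compound 1 to compound 4 (0.16 log units; within the scatter) also stays close, whereas the step of a 3.2-fold lower number from compound 2 to compound 4 (0.50 log units; beyond the scatter) keeps compound 2 and its 4-(trifluoromethyl)phenyl apart from compound 4. No measurement shown here explains the size of these steps.

Open, going by these compounds, is how this position responds to an aryl carrying an amine or a carboxylic acid. Also open, on these data alone, is a longer alkyl chain on the carbonyl carbon in place of the aryl.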